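Replacing an Amide Side Chain with a Trifluoromethylanilide

A few compounds are considered here, and "the series" means these few. Any claim that something is new, unique, unknown or untested is made for them only; others in the source may bear on it.

Compound 2 `CCn1c(C(=O)N(C)CC(=O)O)ccc1C(CC)(CC)c1ccc(OCC(=O)C(C)(C)C)c(C)c1` carries a carboxymethyl(methyl)amide on the shared core. Within the data shown here, in an assay on HL-60 cells for agonist activity at vitamin D3 receptor (Homo sapiens), read by microscopy, with a stated time of 96 h (a lower number here means that less compound is needed, a higher number that more compound is needed for the effect), compound 2 gives 1390 nM, the lowest of the two numbers measured so far. Among the measured compounds shown here, compound 1 `C#CCCOC(=O)c1ccc(C(CC)(CC)c2ccc(OCC(=O)C(C)(C)C)c(C)c2)n1CC`, the corresponding but-3-yn-1-yl ester, gives 28800 nM in this assay, and the single measured step is a 21-fold lower number from compound 1 to compound 2 (1.32 log units; beyond the scatter).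

Compound 3 `CCn1c(C(=O)Nc2cccc(C(F)(F)F)c2)ccc1C(CC)(CC)c1ccc(OCC(=O)C(C)(C)C)c(C)c1` differs from compound 2 by (3-(trifluoromethyl)phenyl)amino in place of (carboxymethyl)(methyl)amino on a carbonyl carbon. For the measured compounds named here, the one step on record changes the same carbonyl carbon, from ester to amide, and is large; no measured pair shows the exchange of one amide substituent for another, so the direction for compound 3 cannot be read from the data. Given that the only comparable change was large, a wide range is expected. Compound 3 is therefore estimated at 1000 nM in this assay, between 150 nM and 8000 nM, which amounts to an expected step of a 1.4-fold lower number from compound 2 to compound 3 (0.14 log units; within the scatter).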

Compound 3, half-maximal effective concentration: > 50000 nM
Compound 3: no number, only a limit; the forecaster's own chance of this, stated with the estimate: 10%; middle value at least 50-fold (1.69 log units) from the limit.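

In this assay, the substituent on the amide matters at this carbonyl carbon: (3-(trifluoromethyl)phenyl)amino in place of (carboxymethyl)(methyl)amino gives an at least 35-fold higher number from compound 2 to compound 3 (1.55 log units; beyond the scatter), so having an amide there does not by itself preserve the lower number of compound 2. The reading for compound 3 is a limit of the assay and not a number: the limit of > 50000 nM in this assay, at which 1 of the 3 values shown sits. Against the ester, the same exchange gives an at least 1.7-fold higher number from compound 1 to compound 3 (0.23 log units; that floor lies within the scatter), and that floor alone does not separate the amide from the ester.

The compounds shown leave open which part of the (carboxymethyl)(methyl)amino group goes with the lower number of compound 2. They also do not show whether a dimethylamino group or an unsubstituted phenylamino group at this carbonyl carbon would fall nearer compound 2 or compound 3.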